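The compounds below may be only part of what the source reports. "The series", "measured", "known", "first", "only" and "open" are said of these compounds alone.

Measured compounds in a functional assay on SMMC-7721 cells (Homo sapiens) for inhibition, read by CCK-8 assay, with a stated time of 72 h, tested at 8 uM; a lower number here means less inhibition of growth, a higher number more inhibition of growth at the concentration tested:
- compound 1, `Nc1ccccc1NC(=O)/C=C/c1ccc(CSc2ccc(F)cc2)cc1`: 15.4%
- compound 2, `CC(C)(C)c1ccc(SCc2ccc(C(=O)Nc3ccccc3N)cc2)cc1`: 46.1%
- compound 3, `COc1ccc(SCc2ccc(C(=O)Nc3ccccc3N)cc2)cc1OC`: 78.9%

Compound 1 stands lowest of the three numbers. Its nearest neighbour on the scale is compound 2, which lies higher by a margin beyond the scatter; compound 3 lies higher still, also beyond the scatter. Within the data shown here, compounds 2 and 3 differ from compound 1 in more than one place, so no single step between measured compounds can be read from these three values; they show only that both of the other compounds reach a higher percent growth inhibition than compound 1.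

The unmeasured compound is compound 4, `CCc1ccc(SCc2ccc(/C=C/C(=O)Nc3ccccc3N)cc2)cc1`. Against compound 1 the difference is ethyl in place of fluoro on an aromatic carbon. The rest of the structure is kept.

Among the measured compounds shown here, no step of this kind is available, so the direction of the change rests on the structural change alone. A small to moderate rise is expected rather than none, as both measured compounds with a carbon substituent in that position give higher numbers than compound 1, though neither is a clean comparison. The step from compound 1 to compound 4 is expected to be a number 14.6 percentage points higher from compound 1 to compound 4 (beyond the scatter). Compound 4 is therefore estimated at 30%, with a range from 10% to 55%.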

Compound 4, percent growth inhibition at one concentration: 19.5%
For compound 4 the middle estimate is 10.5 percentage points above the measured one, and the stated range covers the measured number.
By their numbers in this assay, from the lowest: compounds 1 and 4 (each within the scatter of the next); then compound 2; then compound 3.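

Among these compounds, compound 1 and compound 4 give the first single-place comparison. In this assay, ethyl in place of fluoro on an aromatic carbon, para to a large group, gives a number 4.1 percentage points higher from compound 1 to compound 4 (within the scatter) and so does not separate the two compounds at the concentration tested; on the core of compound 1, the change from 4-fluorophenyl to 4-ethylphenyl leaves no readable effect on percent growth inhibition. No measurement at hand offers an explanation for this outcome.

On these data alone, whether this position tolerates other groups in the same way stays open: an amine, a carboxylic acid or a longer chain such as butyl in place of fluoro could still give a step beyond the scatter, and the present step does not speak to any of them. Also open, as far as these compounds go, is whether ethyl in place of fluoro would give a similar step on the cores of compound 2 and compound 3, which differ from compound 1 in more than one place.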